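The source may hold more compounds than are shown below. What is called first, only, known or untested is meant among the compounds shown, and "the series" means these compounds.

Compound 1 `CS/C(=N\C(=O)c1sccc1Cl)NC(=O)c1sccc1Cl` was tested in a functional assay on HepG2 cells (Homo sapiens) for cytotoxicity, read by MTT assay, with a stated time of 72 h; a higher number here means a weaker inhibitor of growth, a lower number a stronger inhibitor of growth. In this assay compound 1 gives only a limit, > 100000 nM, and the bound itself is all that is known of it (the limit of > 100000 nM in this assay, at which 1 of the 2 values shown sits). A second compound, compound 2 `C[Se]/C(=N\C(=O)c1cnc2ccccc2c1)NC(=O)c1cnc2ccccc2c1`, built on a different core, gives 23700 nM in this assay. The unmeasured compound 3 `C[Se]/C(=N\C(=O)c1sccc1Cl)NC(=O)c1sccc1Cl` keeps the core of compound 1 but carries a group of 2 heavy atoms (1 carbon, 1 selenium; no ring) in place of a group of 2 heavy atoms (1 carbon, 1 sulfur; no ring), on a carbon with a double bond to nitrogen. Among the compounds with values here, with no measured pair to set the size of this change, the step from compound 1 to compound 3 is estimated as an at least 2.0-fold lower number from compound 1 to compound 3 (0.30 log units; that floor lies within the scatter), a move toward stronger growth inhibition that may not clear the scatter. Compound 3 is expected to give about 50000 nM, between 12000 nM and 150000 nM.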

Compound 3, concentration for total growth inhibition: 4020 nM
Compound 3: middle estimate off by 12-fold (1.09 log units), on the high side; the whole stated range lies above it.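

In this assay, on a carbon with a double bond to nitrogen, the selenium-bearing group in place of methylsulfanyl gives an at least 24-fold lower number from compound 1 to compound 3 (1.39 log units; beyond the scatter). This is the first step shown for this position, and it shows that this single exchange on the core of compound 1 can move growth inhibition beyond the scatter. Its full size stays unknown, and compound 1 gives only a limit: the limit of > 100000 nM in this assay, at which 1 of the 3 values shown sits.

The compounds shown leave open whether the same exchange would give a step of like size on the core of compound 2. They also leave open how a longer chain or an amine at this carbon would compare with compound 3.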